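Three Analogues at the Assay Limit, and a Fourth

The compounds below may be only part of what the source reports. "The series", "measured", "known", "first", "only" and "open" are said of these compounds alone.

Measured so far:
Compound 1, `CCC1(c2ccccc2)CC(=O)C(C2CC(c3ccc(-c4ccc(Br)cc4)cc3)Cc3ccccc32)=C(O)O1`, gives > 10000 nM.
Compound 2, `CCC1(c2ccccc2)CC(=O)C(C2CC(c3ccc(OCc4ccc(C(F)(F)F)cc4)cc3)Cc3ccccc32)=C(O)O1`, gives > 10000 nM.
Compound 3, `CCCC1(CCc2ccccc2)CC(=O)C(C2CC(c3ccc(-c4ccc(Br)cc4)cc3)Cc3ccccc32)=C(O)O1`, gives > 10000 nM.

All three values come from a functional assay on HCT-15 cells (Homo sapiens) for inhibition, with a stated time of 72 h; on this read-out lower numbers stand for stronger inhibition and higher numbers for weaker inhibition. The value of compound 1 is a limit of the assay, not a number. The value of compound 2 is likewise a limit. The value of compound 3 is a limit as well. Compound 1 and compound 2 differ by one change: (4-(trifluoromethyl)benzyl)oxy in place of 4-bromophenyl on an aromatic carbon. The step that the two limits leave unreadable from compound 1 to compound 2, because both values sit at the limit of > 10000 nM in this assay, at which 3 of the 3 values shown sit. Compound 3 has a different core from compound 1; the difference between the two cores is not broken down here.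

Compound 4, `CCCC1(CCc2ccccc2)CC(=O)C(C2CC(c3ccc(OCc4ccc(C(F)(F)F)cc4)cc3)Cc3ccccc32)=C(O)O1`, has not yet been measured in this assay. Among the measured compounds shown here, it is derived from compound 3 by (4-(trifluoromethyl)benzyl)oxy in place of 4-bromophenyl on an aromatic carbon, and this is the same change as the one from compound 1 to compound 2, made at the same place. For the measured compounds named here, the only guide to its effect is that in compound 1 it left compound 2 at the limit. Compound 4 is therefore expected to remain at or near the limit, with an expected step that the limit leaves unreadable from compound 3 to compound 4. The estimate for compound 4 in this assay is 20000 nM, with a range from 8000 nM to 60000 nM, and most likely the assay will again report only a limit.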

Compound 4, half-maximal inhibitory concentration: > 10000 nM
Compound 4: only a limit was reported (the forecaster's own chance of this, stated with the estimate: 85%); the middle value is on the limit's open side.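

Compound 3 and compound 4 both sit at a limit of the assay rather than at a number, so no size can be read for the step between them: the limit of > 10000 nM in this assay, at which 4 of the 4 values shown sit.

The compounds shown leave open whether (4-(trifluoromethyl)benzyl)oxy in place of 4-bromophenyl changes inhibition at all in this assay, and which structural change would bring a value within measurable range.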